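The source may report more compounds than this note shows. Statements on the series, on what has been measured and on what is new or still open speak of the compounds shown alone.

Measured compounds in an assay on isolated protein for inhibition of tyrosine-protein phosphatase non-receptor type 13 (Homo sapiens), read by spectrophotometry; a higher number here means a weaker inhibitor, a lower number a stronger inhibitor:
Compound 1, `O=C(COc1ccc2cc(C(O)(C(F)(F)F)C(F)(F)F)c(O)cc2c1)Nc1ccccc1`: for compound 1 the readout is a limit only, > 20000 nM.
Compound 2, `Cc1ccc(S(=O)(=O)NNC(=O)COc2ccc3cc(C(O)(C(F)(F)F)C(F)(F)F)c(O)cc3c2)cc1`: compound 2 gives 14900 nM.

Among the compounds with values here, compound 2 holds the only numbered value in this assay; the other entry is a limit. Within the data shown here, the single measured step is an at least 1.3-fold lower number from compound 1 to compound 2 (0.12 log units; that floor lies within the scatter), and its floor rests on (the limit of > 20000 nM in this assay, at which 1 of the 2 values shown sits).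

Compound 3, `O=C(COc1ccc2cc(C(O)(C(F)(F)F)C(F)(F)F)c(O)cc2c1)NCc1ccc(F)cc1`, differs from compound 2 by 4-fluorobenzyl in place of ((4-methylphenyl)sulfonyl)amino on an amide-type nitrogen. Among the measured compounds shown here, no measured step covers this exact change. What bears on it is that compound 1 carries phenyl on the same amide-type nitrogen and sits at its limit, > 20000 nM. Compound 3 with 4-fluorobenzyl on that nitrogen is closer in shape to compound 1 than to compound 2, which carried the ((4-methylphenyl)sulfonyl)amino group. The expectation is therefore a step back toward weaker inhibition, a 1.7-fold higher number from compound 2 to compound 3 (0.22 log units; within the scatter), with a fair chance that only a limit is reported. Compound 3 is estimated at 25000 nM, within 8000 nM to 80000 nM.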

Compound 3, half-maximal inhibitory concentration: > 20000 nM
Compound 3: only a limit was reported; the forecaster's own chance of this, stated with the estimate: 60%; the middle value lies beyond the limit too.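

In this assay compound 3 gives only a limit, > 20000 nM. Within the data shown here, putting 4-fluorobenzyl in place of ((4-methylphenyl)sulfonyl)amino on the amide-type nitrogen gives an at least 1.3-fold higher number from compound 2 to compound 3 (0.12 log units; that floor lies within the scatter), so this position now has a second group without a numbered value, and compound 2 still holds the only number, although that floor does not separate the two compounds beyond the scatter. Compound 1 and compound 3 each stand at a limit, so the step between them cannot be read, phenyl and 4-fluorobenzyl on this nitrogen cannot be ordered, and the series now stands as follows: the limit of > 20000 nM in this assay, at which 2 of the 3 values shown sit.

As far as these compounds go, whether the ((4-methylphenyl)sulfonyl)amino group truly separates compound 2 from the other two compounds stays open, as the steps touching it have floors that lie within the scatter. Also open, from the compounds shown here alone, is what a primary amine, a carboxylic acid or a longer alkyl chain on the amide-type nitrogen would give. Going by these compounds, compound 2 gives 14900 nM, and whether any such group would leave the scatter around that number stays open too.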